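This account rests on a few compounds, and the source may have more. Where it says the series, first, only, none or still open, it means among the compounds named here.

Three compounds share one core and differ only in the group attached to the aromatic carbon next to the ring nitrogen. In a functional assay on HEK293 cells for activation of melanin-concentrating hormone receptor 1 (Rattus norvegicus), read by inositol phosphate accumulation (a higher number here means that more compound is needed for the effect, a lower number that less compound is needed), compound 1 `CN(c1ccc2cc(NC(=O)CCc3ccc(C(F)(F)F)cc3)ccc2n1)C1CCCCC1` gives 1200 nM, compound 2 `CC(=O)NC1CCN(c2ccc3cc(NC(=O)CCc4ccc(C(F)(F)F)cc4)ccc3n2)C1` gives 440 nM, and compound 3 `NC1CCN(c2ccc3cc(NC(=O)CCc4ccc(C(F)(F)F)cc4)ccc3n2)C1` gives 200 nM, the lowest of the three numbers. The changes were a 2.7-fold lower number from compound 1 to compound 2 (0.44 log units; beyond the scatter), a 6.0-fold lower number from compound 1 to compound 3 (0.78 log units; beyond the scatter) and a 2.2-fold lower number from compound 2 to compound 3 (0.34 log units; beyond the scatter).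

Compound 4 `O=C(CCc1ccc(C(F)(F)F)cc1)Nc1ccc2nc(N3CC4CCC3C4)ccc2c1` is the next step from compound 3: a group of 7 heavy atoms (6 carbon, 1 nitrogen; one five-membered non-aromatic ring of carbon only, one five-membered non-aromatic ring with 1 hetero atom) in place of a group of 6 heavy atoms (4 carbon, 2 nitrogen; one five-membered non-aromatic ring with 1 hetero atom), on an aromatic carbon. Among the compounds with values here, two measured steps bear on this. Removing the acetyl from compound 2 to reach compound 3 lowered the number, and replacing the cyclohexyl(methyl)amino of compound 1 with the aminopyrrolidine lowered it further. Compound 4 goes the other way on both counts, giving up the free amine and returning to a group built largely of carbon rings, so in this assay a modest move towards a higher number is expected, a 3.0-fold higher number from compound 3 to compound 4 (0.48 log units; beyond the scatter). Compound 4 is therefore estimated at 600 nM, within a range of 200 nM to 1800 nM.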

Compound 4, half-maximal effective concentration: 150 nM
For compound 4 the middle estimate is 4.0-fold (0.60 log units) above the measured one, and the stated range ends above it.
By their numbers in this assay, from the lowest: compounds 4 and 3 (each within the scatter of the next); then compound 2; then compound 1.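

In this assay the change at this aromatic carbon gives a 1.3-fold lower number from compound 3 to compound 4 (0.12 log units; within the scatter), so the free amine of the 3-aminopyrrolidin-1-yl group and its hydrogen-bond donor can be given up here without a change beyond the scatter. The same group of compound 4 also gives a 2.9-fold lower number from compound 2 to compound 4 (0.47 log units; beyond the scatter) and an 8.0-fold lower number from compound 1 to compound 4 (0.90 log units; beyond the scatter). Compound 1 and compound 4 both carry groups of carbon rings with a single nitrogen, so that makeup alone does not set the number at this position.

Nothing available explains these differences. Also open, going by these compounds, is where a piperidine, a morpholine or an open-chain diethylamino group at this carbon would fall relative to compound 3 and compound 4.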